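From acetyl to thiophen-2-yl at the assay limit

The compounds below may be only part of what the source reports. "The series", "measured", "known", "first", "only" and "open" are said of these compounds alone.

In a functional assay on AGS cells (Homo sapiens) for inhibition, read by reporter gene assay (on this read-out higher numbers stand for weaker inhibition and lower numbers for stronger inhibition), compound 1 `CC(=O)c1ccc(OCC(=O)Nc2cccc(C(=O)O)c2)cc1` gives > 30000 nM as its result, which is a limit and not a number. Compound 2 `NC(=O)c1cccc(NC(=O)COc2ccccc2)c1` reads > 30000 nM in the same test, again a limit. Compound 3 `NC(=O)c1cccc(NC(=O)COc2ccc([N+](=O)[O-])cc2)c1` reads > 30000 nM as well, also a limit. Among the measured compounds shown here, the whole picture so far is the limit of > 30000 nM in this assay, at which 3 of the 3 values shown sit, and no compound has yet given a number, so compound 1 stands level with the others only in the sense that all three stop at the same limit.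

The next structure is compound 4 `O=C(COc1ccc(-c2cccs2)cc1)Nc1cccc(C(=O)O)c1`, which keeps the core of compound 1 and carries thiophen-2-yl in place of acetyl on an aromatic carbon, para to a large group. The counted change is thiophen-2-yl in place of acetyl on an aromatic carbon and it is the only difference between the two.

For the measured compounds named here, the one measured step with a single change is a step that the two limits leave unreadable from compound 2 to compound 3 and it offers no size to carry over to this new change. Any expectation therefore rests on little. The estimated at least 2.5-fold lower number from compound 1 to compound 4 (0.39 log units; beyond the scatter) in this assay is a modest move towards stronger inhibition, held loosely, and a result that stays at the limit remains quite possible. For compound 4 the estimate is 12000 nM with an expected range from 3000 nM to 30000 nM in this test.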

Compound 4, half-maximal inhibitory concentration: > 30000 nM
Compound 4: a limit, no number (the forecaster's own chance of this, stated with the estimate: 45%); at least 2.5-fold (0.39 log units) between middle value and limit.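

In this assay compound 4 also stops at a limit and gives no number, so the step from compound 1 to compound 4 cannot be read. The series stays where it stood: the limit of > 30000 nM in this assay, at which 4 of the 4 values shown sit. The compounds shown leave open whether thiophen-2-yl in place of acetyl changes inhibition at all, and how strong the inhibition of any of these compounds is.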